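This account rests on a few compounds, and the source may have more. Where it says the series, first, only, none or still open, it means among the compounds named here.

In a functional assay on BJAB cells (Homo sapiens) for antiproliferative activity, with a stated time of 4 days (on this read-out lower numbers stand for an effect already at smaller amounts and higher numbers for an effect only at larger amounts of compound), the three measured compounds give these numbers:

compound 1, `Cc1ccc(-c2c(C)nn(-c3nc(-c4ccc(Cl)c(Cl)c4)c(SC(C)C)s3)c2C(=O)O)cc1`: 3800 nM
compound 2, `Cc1nn(-c2nc(-c3ccc(Cl)c(Cl)c3)c(SC(C)C)s2)c(C(=O)O)c1-c1cncnc1`: 22000 nM
compound 3, `COc1ccc(-c2c(C)nn(-c3nc(-c4ccc(Cl)c(Cl)c4)c(SC(C)C)s3)c2C(=O)O)cc1`: 2100 nM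

Compound 3 sits at the low end of the three, with compound 1 within the scatter of it and compound 2 separated from it by a 10-fold lower number from compound 2 to compound 3 (1.02 log units; beyond the scatter). Compound 4, `Cc1nn(-c2nc(-c3ccc(Cl)c(Cl)c3)c(SC(C)C)s2)c(C(=O)O)c1-c1cnn(C)c1`, differs from compound 3 by 1-methyl-1H-pyrazol-4-yl in place of 4-methoxyphenyl on an aromatic carbon. The step that bears on this is a 5.8-fold higher number from compound 1 to compound 2 (0.76 log units; beyond the scatter), where pyrimidin-5-yl replaced 4-methylphenyl, together with the step from compound 2 to compound 3 already named; both show a higher number when a heteroaryl ring replaces the phenyl. For the measured compounds named here, no measured compound carries a 1-methyl-1H-pyrazol-4-yl, so the size is uncertain. Compound 4 is therefore expected to give a higher number in this assay, a step of about a 4.3-fold higher number from compound 3 to compound 4 (0.63 log units; beyond the scatter). The estimate for compound 4 is 9000 nM, with a range from 3000 nM to 30000 nM.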

Compound 4, half-maximal effective concentration: 6800 nM
Compound 4: the middle estimate sits 1.3-fold (0.12 log units) above what was measured; measured number inside the range.
By their numbers in this assay, from the lowest: compounds 3, 1 and 4 (each within the scatter of the next, the first and the last beyond it); then compound 2.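

In this assay, the 1-methyl-1H-pyrazol-4-yl shows that a heteroaryl ring on this carbon, next to the ring atom that bears a carboxy group, need not read like pyrimidin-5-yl, with a 3.2-fold lower number from compound 2 to compound 4 (0.51 log units; beyond the scatter) between the two. Against the phenyl groups the change splits: a 3.2-fold higher number from compound 3 to compound 4 (0.51 log units; beyond the scatter) lies beyond the scatter, while a 1.8-fold higher number from compound 1 to compound 4 (0.25 log units; within the scatter) lies within it, so a heteroaryl ring here does not always separate from a substituted phenyl. The compounds shown leave open how a longer chain in place of the methyl on the pyrazole nitrogen, or an amine on the phenyl ring, would read at this position. No evidence is available to explain these differences.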